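The source may hold more compounds than are shown below. What is called first, only, known or untested is meant among the compounds shown, and "the series" means these compounds.

In a functional assay on cells (Homo sapiens) for cytotoxicity, read by MTT assay, with a stated time of 48 h (a lower number here means a stronger inhibitor, a higher number a weaker inhibitor), compound 2, `Cc1ccc(CNC(=O)CC2c3ccccc3N=C(N3CCN(CCN(C)C)CC3)N2c2ccc(-c3ccccc3)cc2)cc1`, gives 3520 nM, the higher of the two numbers recorded, while compound 1, `CN(C)CCCCCCN(C)C1=Nc2ccccc2C(CC(=O)NCc2ccccc2)N1c1ccc(-c2ccccc2)cc1`, gives 1740 nM, a gap beyond the scatter. Compound 3, `CN(C)CCN1CCN(C2=Nc3ccccc3C(CC(=O)NCc3ccccc3)N2c2ccc(-c3ccccn3)cc2)CC1`, is reported only as a limit, > 5000 nM, and that limit is noted as the limit of > 5000 nM in this assay, at which 1 of the 3 values shown sits. For the measured compounds named here, compound 4, `CN(C)CCN1CCN(C2=Nc3ccccc3C(CC(=O)NCc3ccccn3)N2c2ccc(-c3ccccc3)cc2)CC1`, carries pyridin-2-yl in place of 4-methylphenyl on a saturated chain carbon bound to an amide-type nitrogen; no measured pair shows this same change. Compound 4 is therefore expected to move from compound 2 by a 1.7-fold higher number from compound 2 to compound 4 (0.23 log units; within the scatter), toward a weaker reading, with a fair chance that this assay returns only a limit. The estimate for compound 4 in this assay is 6000 nM, within a range from 2500 nM to 15000 nM.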

Compound 4, half-maximal inhibitory concentration: > 5000 nM
Compound 4: no number, only a limit; the forecaster's own chance of this, stated with the estimate: 55%; the middle value is on the limit's open side.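

The change from 4-methylphenyl to pyridin-2-yl, on a saturated chain carbon bound to an amide-type nitrogen, is the first step at this place among the compounds shown, and in this assay it gives an at least 1.4-fold higher number from compound 2 to compound 4 (0.15 log units; that floor lies within the scatter). From the compounds shown here alone, the true size of the step stays unknown, and only its floor is fixed. Compound 4 is reported only as a limit, and that limit recurs: the limit of > 5000 nM in this assay, at which 2 of the 4 values shown sit.

The compounds shown leave open how weak compound 4 really is. They also leave open whether 4-chlorophenyl or pyridin-4-yl at this place would return a number rather than a limit.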